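Swapping a Methoxycarbonyl for a Hydroxy on the Shared Core

The compounds below may be only part of what the source reports. "The series", "measured", "known", "first", "only" and "open" are said of these compounds alone.

Of the compounds shown here, three built on one shared core have been tested in a toxicity assay on MDCK cells (Canis lupus familiaris) for cytotoxicity, read by CCK-8 assay, with a stated time of 48 h; a higher number here means that more compound is tolerated, a lower number that less compound is tolerated. Compound 1 `CCOc1ccc(C(=O)NNc2c(Br)cccc2Br)cc1` gives > 100000 nM, which is a limit of the assay and not a number. Compound 3 `O=C(NNc1c(Br)cccc1Br)c1ccc2ccccc2c1` likewise gives only the limit > 100000 nM. Among the measured compounds shown here, compound 2 `COC(=O)c1ccc(C(=O)NNc2c(Br)cccc2Br)cc1` is the one compound with a measured number, 87600 nM. For the measured compounds named here, the one measured step, methoxycarbonyl in place of ethoxy on an aromatic carbon, runs an at least 1.1-fold lower number from compound 1 to compound 2 (0.05 log units; that floor lies within the scatter), so it cannot be told apart from repeat measurements. The picture is framed by the limit of > 100000 nM in this assay, at which 2 of the 3 values shown sit, so small shifts are hard to see at all.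

Compound 4 `O=C(NNc1c(Br)cccc1Br)c1ccc(O)cc1` has not been measured yet. It differs from compound 2 by hydroxy in place of methoxycarbonyl on an aromatic carbon. Going by the values given here, the only measured step swaps a group at this same aromatic carbon and stays within the scatter; on that basis no step beyond the scatter is expected in this assay in either direction, and a result at the limit is the likeliest outcome. Compound 4 is expected to give about 120000 nM, with a range from 60000 nM to 300000 nM. That estimate means an expected step of a 1.4-fold higher number from compound 2 to compound 4 (0.14 log units; within the scatter).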

Compound 4, half-maximal cytotoxic concentration: > 100000 nM
Compound 4 ended at the assay's limit; the forecaster's own chance of this, stated with the estimate: 60%; the middle value is on the limit's open side.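

Hydroxy in place of methoxycarbonyl gives an at least 1.1-fold higher number from compound 2 to compound 4 (0.05 log units; that floor lies within the scatter) in this assay. The earlier step changed this same aromatic carbon, para to a large group, and now a second, quite different swap also shows no step beyond the scatter, even though hydroxy carries a hydrogen-bond donor that methoxycarbonyl lacks and has far fewer heavy atoms. So far, compound 2, compound 1 and compound 4 give no sign that toxicity to these cells depends on the group at this position, but the step from compound 1 to compound 4 cannot be read, and the full size of the other steps stays hidden, because most results are limits of the assay rather than numbers: the limit of > 100000 nM in this assay, at which 3 of the 4 values shown sit.

From the compounds shown here alone, whether an amine, a carboxylic acid or a longer chain on this aromatic carbon would give a clearly lower number remains open. The compounds shown also leave open how much compound these cells would tolerate beyond the limit, so any real differences among compound 1, compound 3 and compound 4 remain out of view.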